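The source may report more compounds than this note shows. Statements on the series, on what has been measured and on what is new or still open speak of the compounds shown alone.

Compound 1 `CCCCN1C(=O)NC2(CSC3=C2C(=O)c2ccccc2C3=O)C1=O`: 178 nM
Compound 2 `O=C1C2=C(C(=O)c3ccccc31)C1(CS2)NC(=O)N(CCO)C1=O`: 69 nM
Compound 3 `NCCN1C(=O)NC2(CSC3=C2C(=O)c2ccccc2C3=O)C1=O`: 22 nM; 20 nM; 31 nM (3 entries)

In a functional assay on MCF7 cells (Homo sapiens) for inhibition (on this read-out lower numbers stand for stronger inhibition and higher numbers for weaker inhibition), compound 1 stands with the higher of the two single numbers given; its nearest neighbour is compound 2, reached by a 2.6-fold lower number from compound 1 to compound 2 (0.41 log units; beyond the scatter). Compound 3 was measured repeatedly, and the several entries of compound 3 in this assay, 22 nM; 20 nM; 31 nM (3 entries) shows numbers smaller than those of compound 1 and compound 2. Compound 4 `NCCCCN1C(=O)NC2(CSC3=C2C(=O)c2ccccc2C3=O)C1=O` follows from compound 1 by amino in place of hydrogen on a saturated chain carbon, four bonds along the chain from an amide-type nitrogen in a ring. For the measured compounds named here, no measured step shows this change itself. Going by the values given here, the one step that bears on it, a 2.6-fold lower number from compound 1 to compound 2 (0.41 log units; beyond the scatter), placed a hydroxy on the chain and gave a modest lower number; compound 3, which also carries an amino on its chain, gives the small numbers noted. A lower number is therefore expected for compound 4 in this assay, by a 4.0-fold lower number from compound 1 to compound 4 (0.60 log units; beyond the scatter). The estimate for compound 4 is 45 nM, ranging from 15 nM to 130 nM.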

Compound 4, half-maximal inhibitory concentration: 35 nM
Compound 4: the middle estimate sits 1.3-fold (0.11 log units) above what was measured; low and high end bracket the measured number.
By their numbers in this assay, from the lowest: compounds 4 and 2 (each within the scatter of the next); then compound 1.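

In this assay, amino in place of hydrogen on the chain now has a measured step of its own: a 5.1-fold lower number from compound 1 to compound 4 (0.71 log units; beyond the scatter). Against the hydroxy-bearing chain the result is a 2.0-fold lower number from compound 2 to compound 4 (0.29 log units; within the scatter), so compound 4 and compound 2 cannot be told apart on this read-out. Compound 3, which also carries an amino on its chain, shows small numbers as well: the several entries of compound 3 in this assay, 22 nM; 20 nM; 31 nM (3 entries)

On these data alone, whether a dimethylamino group or a carboxylic acid on the chain would give similar numbers stays open. So does the effect of a longer chain carrying the amino.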